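Meta-substituted aryl swap on a pyrazole carboxylic acid

The source may hold more compounds than are shown below. What is called first, only, known or untested is meant among the compounds shown, and "the series" means these compounds.

Compound 1 `COc1ccc(-c2c(C)nn(-c3nc(-c4ccc(Cl)c(Cl)c4)c(SC(C)C)s3)c2C(=O)O)cc1`: 2100 nM
Compound 2 `Cc1nn(-c2nc(-c3ccc(Cl)c(Cl)c3)c(SC(C)C)s2)c(C(=O)O)c1-c1cncc(C#N)c1`: 20000 nM
Compound 3 `COc1cc(Cl)cc(-c2c(C)nn(-c3nc(-c4ccc(Cl)c(Cl)c4)c(SC(C)C)s3)c2C(=O)O)c1`: 760 nM

In a functional assay on BJAB cells (Homo sapiens) for antiproliferative activity, with a stated time of 4 days (a higher number here means that more compound is needed for the effect, a lower number that less compound is needed), compound 3 gives the lowest number of the three, with compound 1 next and compound 2 furthest away. Compound 4 `Cc1nn(-c2nc(-c3ccc(Cl)c(Cl)c3)c(SC(C)C)s2)c(C(=O)O)c1-c1cc(C#N)cc(C(F)(F)F)c1` keeps the shared core and changes only the aryl group: 3-cyano-5-(trifluoromethyl)phenyl in place of 3-chloro-5-methoxyphenyl on an aromatic carbon. Within the data shown here, two measured steps bear on this. a 2.8-fold lower number from compound 1 to compound 3 (0.44 log units; beyond the scatter) shows that a meta-substituted phenyl helped, while a 9.5-fold higher number from compound 1 to compound 2 (0.98 log units; beyond the scatter) shows that bringing in a nitrile on the ring hurt, although that step also exchanged the ring itself. Compound 4 combines a meta-substituted phenyl with a nitrile, so a modest upward step is expected in this assay, a 2.0-fold higher number from compound 3 to compound 4 (0.30 log units; within the scatter). Compound 4 is thus estimated at 1500 nM, within 500 nM to 5000 nM.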

Compound 4, half-maximal effective concentration: 3600 nM
Compound 4: the middle estimate sits 2.4-fold (0.38 log units) below what was measured, and the stated range covers the measured number.
By their numbers in this assay, from the lowest: compound 3; then compounds 1 and 4 (each within the scatter of the next); then compound 2.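

In this assay the 3-cyano-5-(trifluoromethyl)phenyl group does not keep the gain seen with 3-chloro-5-methoxyphenyl (a 4.7-fold higher number from compound 3 to compound 4 (0.68 log units; beyond the scatter)), so that gain does not extend to every phenyl group substituted in this pattern. A nitrile on the aryl group need not carry the full cost seen earlier (a 5.6-fold lower number from compound 2 to compound 4 (0.74 log units; beyond the scatter)), although the ring itself changes in that step too. Against the 4-methoxyphenyl group, the new aryl group shows no separation (a 1.7-fold higher number from compound 1 to compound 4 (0.23 log units; within the scatter)).

As far as these compounds go, whether the nitrile or the trifluoromethyl sets the step away from 3-chloro-5-methoxyphenyl remains open, as does the effect of an amine on this ring. No measurement given here explains these steps.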